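Replacing 3-fluorophenyl with pyridin-2-yl in compound 4

The compounds below may be only part of what the source reports. "The series", "measured", "known", "first", "only" and "open" are said of these compounds alone.

Measured so far in an ADME assay (liver) for metabolic stability, with Liver microsome (Homo sapiens) as the target, using microsomes (on this read-out lower numbers stand for slow clearance and higher numbers for fast clearance), for three compounds:
Compound 1 `O=C1Cc2cc(-c3nnc(NCc4ccccc4)o3)ccc2N1` gives < 14 mL.min-1.g-1 as a limit of the assay
Compound 2 `c1ccc(CNc2nnc(-c3c[nH]c4ncccc34)o2)cc1` gives 31 mL.min-1.g-1 as a number
Compound 3 `Fc1cccc(CNc2nnc(-c3c[nH]c4ncccc34)o2)c1` gives 54 mL.min-1.g-1 as a number

Compound 3 at 54 mL.min-1.g-1 lies within the scatter of compound 2 at 31 mL.min-1.g-1 and the two cannot be told apart. Within the data shown here, compound 1 has a different core and offers no step here.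

Compound 4 `c1ccc(CNc2nnc(-c3c[nH]c4ncccc34)o2)nc1` keeps the core of compound 3 and carries pyridin-2-yl in place of 3-fluorophenyl on a saturated chain carbon bound to a nitrogen on an aromatic ring. Among the measured compounds shown here, only one measured step touches this ring: fluoro in place of hydrogen on an aromatic carbon (a 1.7-fold higher number from compound 2 to compound 3 (0.24 log units; within the scatter)), and it stayed within the scatter. For the measured compounds named here, no measured step covers a swap of the whole ring, so the expectation is uncertain. Compound 4 has no fluoro, and compound 2 at 31 mL.min-1.g-1 leans the expectation towards that value. No step beyond the scatter is expected in this assay although the direction is expected to be towards a lower number. The expected step is a 1.9-fold lower number from compound 3 to compound 4 (0.29 log units; within the scatter) and no larger. The estimate for compound 4 is 28 mL.min-1.g-1 (expected range 13 mL.min-1.g-1 to 55 mL.min-1.g-1).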

Compound 4, intrinsic clearance in microsomes: < 14 mL.min-1.g-1
Compound 4 was reported as a limit (the forecaster's own chance of this, stated with the estimate: 15%); middle value at least 2.0-fold (0.30 log units) from the limit.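

In this assay, putting pyridin-2-yl on a saturated chain carbon bound to a nitrogen on an aromatic ring gives a clear change: the swap from 3-fluorophenyl is an at least 3.8-fold lower number from compound 3 to compound 4 (0.58 log units; beyond the scatter), and the swap from phenyl is an at least 2.2-fold lower number from compound 2 to compound 4 (0.34 log units; beyond the scatter). Among these compounds, both steps lie beyond the scatter, whereas the only earlier step on this ring, a 1.7-fold higher number from compound 2 to compound 3 (0.24 log units; within the scatter), stayed within it, so replacing the whole ring shows what the fluoro change could not. The value of compound 4 is a limit of the assay, and the full size of both steps cannot be read because of it: the limit of < 14 mL.min-1.g-1 in this assay, at which 2 of the 4 values shown sit.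

On these data alone, it remains open whether pyridin-3-yl or pyridin-4-yl would match pyridin-2-yl at this place. A saturated ring such as piperidin-4-yl is also untested among the compounds shown.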